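A Second Chloro Added to the Core of Compound 2

The compounds below may be only part of what the source reports. "The series", "measured", "known", "first", "only" and "open" are said of these compounds alone.

Of the compounds shown here, two have been measured in a functional assay on CCRF-CEM cells (Homo sapiens) for cytotoxicity, read by sulforhodamine B assay, with a stated time of 48 h; on this read-out lower numbers stand for higher toxicity in this test and higher numbers for lower toxicity in this test. Among the compounds with values here, compound 1 `ClCc1ccc(Cn2cnc3nc(Cl)nc(Cl)c32)cc1` gives 66100 nM in this assay, while compound 2 `ClCc1ccccc1Cn1cnc2ncnc(Cl)c21` gives 8700 nM in this assay, the lower of the two numbers, and the gap between them lies beyond the usual scatter; the two structures differ in more than one place, so no single step connects them.

Compound 3 `ClCc1ccccc1Cn1cnc2nc(Cl)nc(Cl)c21` has not yet been measured. It differs from compound 2 by chloro in place of hydrogen on an aromatic carbon, on the aromatic carbon of the core that sits between two ring nitrogen atoms. Within the data shown here, no measured pair shows this change on its own. Among the measured compounds shown here, the only other compound carrying two chloro groups on the core, compound 1, sits at the weak end with 66100 nM, but it also carries a different benzyl pattern, so the expected effect is uncertain. A modest loss of potency, a 1.8-fold higher number from compound 2 to compound 3 (0.26 log units; within the scatter), is expected. For compound 3 the estimate in this assay is 16000 nM, within a range from 4000 nM to 60000 nM.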

Compound 3, concentration lethal to 50% of the cells: 930 nM
Estimate against measurement, compound 3: 17-fold (1.24 log units) above, and the stated range ends above it.
By their numbers in this assay, from the lowest: compound 3; then compound 2; then compound 1.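

Chloro in place of hydrogen on the aromatic carbon between two ring nitrogen atoms gives a 9.4-fold lower number from compound 2 to compound 3 (0.97 log units; beyond the scatter) in this assay, the first single change read at this position. It shows that, with the benzyl pattern of compound 2, this chloro group goes with a lower number, not a higher one. Compound 1, which also carries two chloro groups on the core but has a different benzyl pattern, gives 66100 nM, so a second chloro on the core does not bring a low number by itself, and nothing measured here explains the step.

The compounds shown leave open whether an amine or a methoxy group on this same carbon would move the number as chloro does. They also leave open how the number would respond if an amine replaced the other chloro on the core.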